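The compounds below may be only part of what the source reports. "The series", "measured", "known", "first", "only" and "open" are said of these compounds alone.

The measured compounds:
compound 1, `CCCC(=O)Nc1cccc(S(=O)(=O)Oc2ccccc2C(C)C)c1`, 15000 nM
compound 2, `CC(C)c1ccccc1OS(=O)(=O)c1cccc(NC(=O)CCl)c1`, 780 nM
compound 3, `CC(=O)Nc1ccc(S(=O)(=O)Oc2ccccc2C(C)C)cc1`, 12000 nM

All three were tested in a functional assay on HT-1080 cells (Homo sapiens) for antiproliferative activity, read by sulforhodamine B assay, with a stated time of 48 h; a higher number here means a weaker inhibitor, a lower number a stronger inhibitor. For the measured compounds named here, compound 1 gives 15000 nM and compound 2 gives 780 nM; the only single change among the measured set, a 19-fold lower number from compound 1 to compound 2 (1.28 log units; beyond the scatter), concerns chloro in place of ethyl on a saturated chain carbon bound to a carbonyl carbon. Compound 3, with 12000 nM, stands second highest of the three numbers; compound 1 is its nearest, within the scatter, and compound 2 its furthest, beyond the scatter.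

Compound 4, `CC(=O)Nc1ccc(S(=O)(=O)Oc2ccccc2I)cc1`, has not yet been measured. It differs from compound 3 by iodo in place of isopropyl on an aromatic carbon of a six-membered aromatic ring of carbon only, ortho to a large group. Going by the values given here, no measured step bears on this change: the one known step sits on a saturated chain carbon, not on an aromatic carbon. With nothing to draw on, the step of no change at the digits printed from compound 3 to compound 4 (within the scatter) is expected to stay within the scatter, in no particular direction. Compound 4 is therefore estimated at 12000 nM, with a range from 3000 nM to 45000 nM.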

Compound 4, half-maximal inhibitory concentration: 17000 nM
Compound 4: the middle estimate sits 1.4-fold (0.15 log units) below what was measured; the measured number falls inside the stated range.
By their numbers in this assay, from the lowest: compound 2; then compounds 3, 1 and 4 (each within the scatter of the next).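

In this assay, for the compounds shown here, the step of a 1.4-fold higher number from compound 3 to compound 4 (0.15 log units; within the scatter) gives the first reading at this aromatic carbon, since the earlier step concerned a saturated chain carbon. At this place, ortho to a large group, iodo with 1 heavy atom stands in place of isopropyl with 3 heavy atoms, and the number stays within the scatter. The compounds shown offer no measurement that explains this result.

From the compounds shown here alone, whether an amine or a carboxylic acid on the same aromatic carbon would also stay within the scatter remains open. Going by these compounds, it is also open whether chloro on the saturated chain carbon bound to the carbonyl carbon of compound 4 would bring a step of the size seen in a 19-fold lower number from compound 1 to compound 2 (1.28 log units; beyond the scatter).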